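A few compounds are considered here, and "the series" means these few. Any claim that something is new, unique, unknown or untested is made for them only; others in the source may bear on it.

Compound 1 `COc1cc(-c2coc3cc(O)cc(O)c3c2=O)ccc1O`: > 50000 nM (a limit of the assay, not a number)
Compound 2 `COc1cc(-c2coc3cc(O)ccc3c2=O)ccc1O`: 39800 nM

Among the compounds with values here, in a functional assay on BV-2 cells (Mus musculus) for inhibition (on this read-out lower numbers stand for stronger inhibition and higher numbers for weaker inhibition), compound 2 holds the only actual number so far, 39800 nM. Compound 3 `COc1cc(-c2coc3cc(O)ccc3c2=O)cc(OC)c1O` differs from it by methoxy in place of hydrogen on an aromatic carbon, ortho to a hydroxy group. Within the data shown here, the one measured step, an at least 1.2-fold lower number from compound 1 to compound 2 (0.09 log units; that floor lies within the scatter), swaps a different group at a different place, so it offers only weak guidance. No step beyond the scatter is therefore expected, and the estimated step is a 1.1-fold lower number from compound 2 to compound 3 (0.06 log units; within the scatter). For compound 3 the estimated value is 35000 nM, with an expected range of 12000 nM to 60000 nM.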

Compound 3, half-maximal inhibitory concentration: > 50000 nM
Compound 3: no number, only a limit; the forecaster's own chance of this, stated with the estimate: 35%; at least 1.4-fold (0.15 log units) between middle value and limit.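

Within the data shown here, this is the first change on the ring that carries the hydroxy group, and in this assay it gives an at least 1.2-fold higher number from compound 2 to compound 3 (0.09 log units; that floor lies within the scatter). Compound 3 has only a limit of the assay, so that step is a floor: methoxy ortho to a hydroxy group shows no sign of stronger inhibition, but its true effect may be nil or larger. Little can be read from this comparison, as most values reach the end of the measurable range: the limit of > 50000 nM in this assay, at which 2 of the 3 values shown sit.

As far as these compounds go, how far compound 3 truly lies past its limit stays open. So does whether an amine or a longer chain such as ethoxy at this place would lower the number.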